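Swapping the sulfonyl aryl group on two related cores

The source may hold more compounds than are shown below. What is called first, only, known or untested is meant among the compounds shown, and "the series" means these compounds.

Measured compounds:
compound 1, `O=S(=O)(c1cc(Cl)cc(Cl)c1)c1cnc2cc(F)ccc2c1-c1ccc(F)cc1`, gives 0.18 mL/min in an ADME assay on microsomes from liver (Homo sapiens) for metabolic stability, tested at 2.5 uM; on this read-out lower numbers stand for slow clearance and higher numbers for fast clearance
compound 2, `O=S(=O)(c1cc(Cl)cc(Cl)c1)c1cnc2c(F)cccc2c1-c1ccccc1F`, gives 0.44 mL/min in this assay
compound 3, `O=S(=O)(c1cccc(F)c1)c1cnc2cc(F)ccc2c1-c1ccc(F)cc1`, gives 0.11 mL/min in this assay

Compound 3 differs from compound 1 by 3-fluorophenyl in place of 3,5-dichlorophenyl on a sulfonyl sulfur, and this change made a step of a 1.6-fold lower number from compound 1 to compound 3 (0.21 log units; within the scatter) in this assay. Compound 2 carries the same sulfonyl aryl group as compound 1 but on a different core; the difference between the two cores is not broken down here. Compound 2 stands highest of the three measured numbers, and its gap to compound 1 and to compound 3 lies beyond the scatter.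

Compound 4, `O=S(=O)(c1cccc(F)c1)c1cnc2c(F)cccc2c1-c1ccccc1F`, is not yet measured. It differs from compound 2 by 3-fluorophenyl in place of 3,5-dichlorophenyl on a sulfonyl sulfur, the same change, at the same place, that turns compound 1 into compound 3. Among the compounds with values here, it is expected that the step from compound 2 to compound 4 in this assay is of about the same size as the earlier one, a 1.6-fold lower number from compound 2 to compound 4 (0.21 log units; within the scatter), resting on the single measured example a 1.6-fold lower number from compound 1 to compound 3 (0.21 log units; within the scatter). The number for compound 4 is accordingly estimated at 0.27 mL/min, with a range from 0.12 mL/min to 0.6 mL/min.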

Compound 4, intrinsic clearance in a liver preparation (reported as CLH), per the amount of preparation that the assay uses: 0.21 mL/min
Estimate against measurement, compound 4: 1.3-fold (0.11 log units) above; measured number inside the range.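

Putting 3-fluorophenyl in place of 3,5-dichlorophenyl on a sulfonyl sulfur of the core of compound 2 makes a step of a 2.1-fold lower number from compound 2 to compound 4 (0.32 log units; beyond the scatter) in this assay. Set beside the earlier step, the change carries over from one core to the other with no difference that can be told apart: the same change on two cores in this assay, a 1.6-fold lower number (0.21 log units; within the scatter) from compound 1 to compound 3 and a 2.1-fold lower number (0.32 log units; beyond the scatter) from compound 2 to compound 4, 1.3-fold (0.11 log units) apart, within the scatter of two such steps. Within the data shown here, this agreement rests on only two pairs of compounds, and the earlier step on its own lies within the scatter, so it does not show that the change would behave the same way on a third core, nor does it explain why either step has its size.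

The compounds shown leave open how other groups on the sulfonyl sulfur would read in this assay, such as a plain phenyl or an aryl ring carrying an amine or a carboxylic acid. They also leave open which of the differences between the two cores accounts for the gap between compound 1 and compound 2.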